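The compounds below may be only part of what the source reports. "The series", "measured", "known", "first", "only" and "open" are said of these compounds alone.

Measured compounds:
- compound 1 `O=C(CCCc1ccccc1)Nc1nc2ccccc2c(=O)s1`: > 1000 nM
- compound 2 `O=C(C/C=C/c1cccc(Cl)c1)Nc1nc2ccccc2c(=O)s1`: > 1000 nM
- compound 3 `O=C(C/C=C/c1ccccc1)Nc1nc2ccccc2c(=O)s1`: 119 nM

In an assay on CHO cells for displacement of a labelled ligand from adenosine receptor A2b (Homo sapiens), read by scintillation counting, with a stated time of 75 min (on this read-out higher numbers stand for weaker inhibition and lower numbers for stronger inhibition), compound 3 gives 119 nM. For compound 2 only a limit is reported, > 1000 nM. For compound 1 likewise only a limit is reported, > 1000 nM. Among the compounds with values here, the one counted step is an at least 8.4-fold higher number from compound 3 to compound 2 (0.92 log units; beyond the scatter), the change being (chloro in place of hydrogen on an aromatic carbon).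

Compound 4 `O=C(CCCc1ccccc1)Nc1nc2cc(Cl)ccc2c(=O)s1` is not yet measured. It differs from compound 1 by chloro in place of hydrogen on an aromatic carbon. This is the same kind of change as from compound 3 to compound 2, but not the same: in compound 2 the chloro sits on a six-membered aromatic ring of carbon only, meta to a large group, whereas in compound 4 it sits on a ring that is part of a fused or bridged system of two rings, meta to a fused ring and para to a fused ring. The difference between the core of compound 1 and the core of compound 3 is not broken down here.

Within the data shown here, compound 1 already stands at the limit of > 1000 nM in this assay, at which 2 of the 3 values shown sit, and the one measured chloro step raised the number. The expected step from compound 1 to compound 4 in this assay is therefore a step that the limit leaves unreadable from compound 1 to compound 4, resting on an at least 8.4-fold higher number from compound 3 to compound 2 (0.92 log units; beyond the scatter) and on (the limit of > 1000 nM in this assay, at which 2 of the 3 values shown sit). Compound 4 is estimated at 3000 nM, between 1000 nM and 10000 nM, most likely again only a limit.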

Compound 4, inhibition constant: > 1000 nM
Compound 4 gave a limit, no number; the forecaster's own chance of this, stated with the estimate: 85%; the middle value lies beyond the limit too.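

Within the data shown here, compound 1 and compound 4 both stand only as limits, so no step between them can be read: the limit of > 1000 nM in this assay, at which 3 of the 4 values shown sit.

The compounds shown leave open whether chloro in place of hydrogen on the shared core changes the read-out at all, and how far past the limit either compound lies.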